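The source may hold more compounds than are shown below. What is called first, only, known or untested is meant among the compounds shown, and "the series" means these compounds.

Measured compounds in an assay on HL-60 cells for inhibition of glutathione S-transferase P (Homo sapiens); on this read-out lower numbers stand for stronger inhibition and higher numbers for weaker inhibition:
- compound 1 `C=C(C)C(=O)c1ccc(OCc2nc(-c3ccc(C(F)(F)F)cc3)no2)cc1Br` gives 1300 nM
- compound 2 `C=C(CC)C(=O)c1ccc(OCc2nc(C)no2)c(Cl)c1Cl` gives 4000 nM
- compound 3 `C=C(CC)C(=O)c1ccc(OCc2nc(-c3ccc(C(F)(F)F)cc3)no2)c(Cl)c1Cl` gives only a limit of the assay, > 40000 nM

Of the two numbers shown, compound 1 has the lowest, the stronger inhibition; compound 2 sits higher, beyond the usual scatter. Compound 3 is known only as a limit (the limit of > 40000 nM in this assay, at which 1 of the 3 values shown sits).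

Compound 4 `C=C(C)C(=O)c1ccc(OCc2nc(-c3ccccc3)no2)cc1Br` differs from compound 1 in one place: hydrogen in place of trifluoromethyl on an aromatic carbon. For the measured compounds named here, the only measured step that touches the same part of the molecule is the one an at least 10-fold higher number from compound 2 to compound 3 (1.00 log units; beyond the scatter), where a whole 4-(trifluoromethyl)phenyl took the place of methyl on the shared core of compound 2. Going by the values given here, that step does not separate the trifluoromethyl from the phenyl it sits on, so no measured pair shows what removing trifluoromethyl alone does. Against that background the change from compound 1 to compound 4 is expected to shift this assay only modestly, with no firm direction, and the estimate stays close to compound 1 with a wide range: compound 4 is expected at 2000 nM, between 600 nM and 8000 nM, meaning an expected step of a 1.5-fold higher number from compound 1 to compound 4 (0.19 log units; within the scatter).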

Compound 4, half-maximal inhibitory concentration: 2000 nM
Beside the measured number, compound 4's estimate shows no gap at the digits printed; low and high end bracket the measured number.
By their numbers in this assay, from the lowest: compounds 1, 4 and 2 (each within the scatter of the next, the first and the last beyond it). At a limit, above all of these: compound 3.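

For the compounds shown here, this is the first pair that isolates the trifluoromethyl from the phenyl ring it sits on: in this assay, putting hydrogen in its place gives a 1.5-fold higher number from compound 1 to compound 4 (0.19 log units; within the scatter), so on the core of compound 1 this group can go without a change that repeat measurements could tell apart. The earlier step, an at least 10-fold higher number from compound 2 to compound 3 (1.00 log units; beyond the scatter), swapped a methyl for the whole 4-(trifluoromethyl)phenyl on the shared core of compound 2, and it could not say which part of that group went with the step; the new pair shows that the trifluoromethyl alone, on a different core, comes with no step beyond the scatter. No measurement shown here gives a reason for this result.

The compounds shown leave open what a methoxy, a nitrile or an amine would do on this aromatic carbon, where only trifluoromethyl and hydrogen appear so far. Also open, as far as these compounds go, is how hydrogen in place of trifluoromethyl would read on the core of compound 3, which is known only as a limit of the assay.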